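Thiazole in place of sulfonamide on the bicyclic core

This account rests on a few compounds, and the source may have more. Where it says the series, first, only, none or still open, it means among the compounds named here.

The series shares one core carrying an imidazole. Compound 1 `Cc1n[nH]cc1-c1cccc2c1CCC2c1ncc[nH]1` bears a 3-methyl-1H-pyrazol-4-yl group on the aromatic ring; in a functional assay on CHO cells for agonist activity at Alpha-1A adrenergic receptor (Homo sapiens), read by FLIPR and calcium flux (on this read-out lower numbers stand for an effect already at smaller amounts and higher numbers for an effect only at larger amounts of compound), compound 1 gives 3 nM. For the measured compounds named here, compound 2 `CS(=O)(=O)Nc1cccc2c1CCC2c1ncc[nH]1` carries a methanesulfonamido group at the same place, and in this assay compound 2 gives 70 nM, the higher of the two numbers measured so far. The change between them is a 23-fold higher number from compound 1 to compound 2 (1.37 log units; beyond the scatter).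

Compound 3 `c1cc(-c2nccs2)c2c(c1)C(c1ncc[nH]1)CC2` is the next candidate. The change from compound 2 to compound 3 is 1,3-thiazol-2-yl in place of methanesulfonamido on an aromatic carbon. Going by the values given here, only one measured step bears on this: the move from compound 1 to compound 2, in which swapping an aromatic five-membered ring for the methanesulfonamido group raised the number markedly. Compound 3 goes the other way, putting a five-membered aromatic ring back in that place, so a step back toward the number of compound 1 is expected, though the new ring is not identical to the pyrazole of compound 1 and carries no hydrogen-bond donor. For compound 3 the expected result is 8 nM, within 2 nM to 40 nM, meaning an expected step of an 8.8-fold lower number from compound 2 to compound 3 (0.94 log units; beyond the scatter).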

Compound 3, half-maximal effective concentration: 426 nM
For compound 3 the middle estimate is 53-fold (1.73 log units) below the measured one; measured number outside the range, above it.
By their numbers in this assay, from the lowest: compound 1; then compound 2; then compound 3.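

In this assay the 1,3-thiazol-2-yl group gives a 6.1-fold higher number from compound 2 to compound 3 (0.78 log units; beyond the scatter) and so does not recover the low number of compound 1. Putting a five-membered aromatic ring on this aromatic carbon is therefore not enough in itself: the comparison between the two rings shows a 140-fold higher number from compound 1 to compound 3 (2.15 log units; beyond the scatter) and makes this the largest step among the three compounds, with methanesulfonamido falling between the two rings in the order of the numbers. The position thus separates two five-membered aromatic rings very sharply, but nothing measured here accounts for the gap or for the thiazole lying above the sulfonamide.

The three compounds leave open which feature of the 3-methyl-1H-pyrazol-4-yl group carries its low number, since its ring and its methyl group are both absent from compound 3. A pyrazole without the methyl group, an oxazole, or a simple amine at the same place would help to show how much of the step belongs to the ring itself and how much to what it carries.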